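A few compounds are considered here, and "the series" means these few. Any claim that something is new, unique, unknown or untested is made for them only; others in the source may bear on it.

Compound 1 `COc1cc2nc(N3CCCC3)nc(NS(=O)(=O)c3ccc(C)cc3)c2cc1OC` gives 24.1 ug/mL in a functional assay on COLO 205 cells (Homo sapiens) for cytotoxicity, read by MTT assay, with a stated time of 24 h (on this read-out lower numbers stand for stronger inhibition and higher numbers for weaker inhibition), the lowest of the three numbers in hand. Compound 2 `COc1cc2nc(Cl)nc(NS(=O)(=O)c3ccc(C)cc3C)c2cc1OC` gives 49 ug/mL in this assay, and compound 3 `COc1cc2nc(Cl)nc(NS(=O)(=O)c3ccc(C)cc3)c2cc1OC` gives 91.3 ug/mL in this assay. Of the two single-point steps between them, a 3.8-fold higher number from compound 1 to compound 3 (0.58 log units; beyond the scatter) concerns the core and lies beyond the scatter, while a 1.9-fold higher number from compound 2 to compound 3 (0.27 log units; within the scatter) concerns the aryl on the sulfonyl sulfur and stays within it.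

Compound 4 `COc1cc2nc(N3CCCC3)nc(NS(=O)(=O)c3cccc(C(F)(F)F)c3)c2cc1OC` differs from compound 1 by 3-(trifluoromethyl)phenyl in place of 4-methylphenyl on a sulfonyl sulfur. Going by the values given here, the only measured step bearing on this position is the one from compound 2 to compound 3, and it moved nothing beyond the scatter. Among the compounds with values here, no measured step covers a trifluoromethyl group, so the direction of any larger effect cannot be read from these data. The step expected in this assay is therefore a 1.0-fold lower number from compound 1 to compound 4 (0.00 log units; within the scatter), essentially none beyond the scatter, with a wide range to cover the untested group. Compound 4 is expected at 24 ug/mL, within 9 ug/mL to 65 ug/mL.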

Compound 4, half-maximal inhibitory concentration: 78 ug/mL
Compound 4: the middle estimate sits 3.3-fold (0.51 log units) below what was measured, outside the stated range (above it).
By their numbers in this assay, from the lowest: compound 1; then compounds 2, 4 and 3 (each within the scatter of the next).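

On the core of compound 1, the group on the sulfonyl sulfur does matter in this assay: 3-(trifluoromethyl)phenyl in place of 4-methylphenyl gives a 3.2-fold higher number from compound 1 to compound 4 (0.51 log units; beyond the scatter), whereas the earlier step at this position, a 1.9-fold higher number from compound 2 to compound 3 (0.27 log units; within the scatter), stayed within the scatter. The step moves towards weaker inhibition, so of these two groups 4-methylphenyl gives the lower number on this core, although the change swaps the substituent and its printed ring position together. The data offer no measured property that would account for this shift.

A 3-methylphenyl or a 4-(trifluoromethyl)phenyl group on the same core would separate the effect of the group from that of its position. On these data alone, how an aryl carrying an amine or a carboxylic acid would read at this sulfur remains open.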